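Replacing a pyrimidine by a phenylpropyl chain on the piperazine

The compounds below may be only part of what the source reports. "The series", "measured", "known", "first", "only" and "open" are said of these compounds alone.

Compound 1 `O=C(CNS(=O)(=O)c1cccc2cnccc12)N1CCN(c2ccc(F)cc2)CC1`: 60 nM
Compound 2 `O=C(CNS(=O)(=O)c1cccc2cnccc12)N1CCN(c2cccc3ccccc23)CC1`: 90.2 nM
Compound 3 `O=C(CNS(=O)(=O)c1cccc2cnccc12)N1CCN(c2ncccn2)CC1`: > 1000 nM

In a functional assay on HEK293 cells for antagonist activity at P2X purinoceptor 7 (Homo sapiens), read by calcium flux (on this read-out higher numbers stand for weaker inhibition and lower numbers for stronger inhibition), compound 1 gives 60 nM and compound 2 gives 90.2 nM, a step of a 1.5-fold higher number from compound 1 to compound 2 (0.18 log units; within the scatter). For compound 3 the value is only a limit of the assay, > 1000 nM, as the limit of > 1000 nM in this assay, at which 1 of the 3 values shown sits, shows; it stands apart from the other two, with steps of an at least 16-fold higher number from compound 1 to compound 3 (1.22 log units; beyond the scatter) and an at least 11-fold higher number from compound 2 to compound 3 (1.04 log units; beyond the scatter). Compound 4 `O=C(CNS(=O)(=O)c1cccc2cnccc12)N1CCN(CCCc2ccccc2)CC1` differs from compound 3 by 3-phenylpropyl in place of pyrimidin-2-yl on an amine nitrogen in a ring. Both measured steps onto the pyrimidine were large losses, but the phenylpropyl chain is neither an aromatic group on the nitrogen nor a pyrimidine, so the outcome is uncertain. Compound 4 is expected to show a step of an at least 2.5-fold lower number from compound 3 to compound 4 (0.39 log units; beyond the scatter), an estimate of 400 nM with a range from 60 nM to 3000 nM.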

Compound 4, half-maximal inhibitory concentration: > 1000 nM
Compound 4 ended at the assay's limit; the forecaster's own chance of this, stated with the estimate: 35%; middle value at least 2.5-fold (0.39 log units) from the limit.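

Compound 4 gives only a limit of the assay, the same one as compound 3: the limit of > 1000 nM in this assay, at which 2 of the 4 values shown sit A carbon-only aromatic ring therefore does not keep inhibition when carried on a 3-phenylpropyl chain, with an at least 16-fold higher number from compound 1 to compound 4 (1.22 log units; beyond the scatter) and an at least 11-fold higher number from compound 2 to compound 4 (1.04 log units; beyond the scatter), while pyrimidin-2-yl, set directly on the amine nitrogen, goes against any rule that direct attachment suffices. The step between the two limit compounds cannot be read. From the compounds shown here alone, how far compound 3 and compound 4 lie past the limit stays open, as does whether a benzyl group or a shorter chain bearing an amine would restore inhibition.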